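The source may report more compounds than this note shows. Statements on the series, on what has been measured and on what is new or still open speak of the compounds shown alone.

In a functional assay on brain (Rattus norvegicus, strain Wistar) for inhibition (a lower number here means a stronger inhibitor, a higher number a weaker inhibitor), compound 1 `Cc1[nH]c(=O)n(C)c1-c1ccccc1` gives > 100000 nM as a limit of the assay and not as a number. Going by the values given here, compound 2 `CCCCc1ccc(-c2c(C)[nH]c(=O)n2C)cc1` gives 10700 nM and so stands alone as the only true number so far. Compound 3 `CCCCOc1ccc(-c2c(C)[nH]c(=O)n2C)cc1` differs from it in one place, with butoxy in place of butyl on an aromatic carbon while the rest of the molecule stays the same. Among the compounds with values here, only one measured step bears on this change. Putting butyl in place of hydrogen at that same carbon gave an at least 9.3-fold lower number from compound 1 to compound 2 (0.97 log units; beyond the scatter) and lies beyond the scatter, so a chain at this carbon matters in compound 2. Butoxy keeps a chain there and adds one oxygen, so the gain seen with compound 2 is expected to survive, though no measured step shows what that oxygen does. The expected change is a 1.2-fold lower number from compound 2 to compound 3 (0.08 log units; within the scatter) and this estimate stays within the scatter. For compound 3 the estimated value is 9000 nM with an expected range from 2500 nM to 35000 nM in this assay.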

Compound 3, half-maximal inhibitory concentration: 5100 nM
Compound 3: the middle estimate sits 1.8-fold (0.25 log units) above what was measured; low and high end bracket the measured number.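

Until now, the compounds showed only that having a chain on this aromatic carbon matters. In this assay, butoxy in place of butyl gives a 2.1-fold lower number from compound 2 to compound 3 (0.32 log units; beyond the scatter), so what the chain is made of counts as well, even though this step is modest. On these data alone, measured against the hydrogen of the parent compound, butoxy gives an at least 19-fold lower number from compound 1 to compound 3 (1.29 log units; beyond the scatter), and this is the largest change seen at this carbon, though its true size is unknown. Compound 1 stands at a limit and not at a number: the limit of > 100000 nM in this assay, at which 1 of the 3 values shown sits.

Butoxy differs from butyl both by its oxygen and by its extra heavy atom, so it remains open whether the gain belongs to the oxygen or simply to a longer chain, and a pentyl group at this carbon would tell the two apart. Also open, as far as these compounds go, is how a shorter methoxy group, or a chain ending in an amine or a carboxylic acid, would behave at the same carbon.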